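Swapping the amide aryl group on a benzimidazole-linked scaffold

A few compounds are considered here, and "the series" means these few. Any claim that something is new, unique, unknown or untested is made for them only; others in the source may bear on it.

Two compounds share one core and differ only in the aromatic group attached to the carbonyl carbon of the amide. Compound 1 `O=C(NCc1cccc(Cn2cnc3ccccc32)c1)c1cc(Br)c[nH]1` carries a brominated pyrrole there, and in an assay on MCF7 cells for inhibition of Indoleamine 2,3-dioxygenase 1 (Homo sapiens), read by HPLC, with a stated time of 48 h (a higher number here means a weaker inhibitor, a lower number a stronger inhibitor), compound 1 gives 21 nM. Compound 2 `O=C(NCc1cccc(Cn2cnc3ccccc32)c1)c1cc2ccccc2[nH]1` carries an indole instead, and in this assay compound 2 gives 83 nM, the highest of the two numbers measured, with a 4.0-fold higher number from compound 1 to compound 2 (0.60 log units; beyond the scatter). Compound 3 `N#Cc1ccc(C(=O)NCc2cccc(Cn3cnc4ccccc43)c2)cc1` has not been measured; it differs from compound 2 by 4-cyanophenyl in place of 1H-indol-2-yl on a carbonyl carbon. Going by the values given here, no measured step covers this particular exchange, so the only guide is that the one exchange at this carbonyl carbon moved the number modestly. Compound 3 is therefore expected to give about 200 nM in this assay, within a range from 50 nM to 800 nM. That estimate corresponds to a 2.4-fold higher number from compound 2 to compound 3 (0.38 log units; beyond the scatter), with a wide margin on either side.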

Compound 3, half-maximal inhibitory concentration: 110 nM
The estimate for compound 3 lay 1.8-fold (0.26 log units) above the measured number; low and high end bracket the measured number.
By their numbers in this assay, from the lowest: compound 1; then compounds 2 and 3 (each within the scatter of the next).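

Exchanging a two-ring group that has a hydrogen-bond donor for a single six-membered ring with a nitrile and no donor gives a 1.3-fold higher number from compound 2 to compound 3 (0.12 log units; within the scatter) in this assay, so on this carbonyl carbon the two groups cannot be told apart. The 4-bromo-1H-pyrrol-2-yl group still stands apart from 4-cyanophenyl, with a 5.2-fold higher number from compound 1 to compound 3 (0.72 log units; beyond the scatter), so this position does respond to the group placed on it, though not to every exchange. Nothing available explains why these numbers fall as they do.

The compounds shown cannot separate the part played by the bromine in compound 1 from that of the pyrrole ring, since a plain 1H-pyrrol-2-yl group is not among them. On these data alone, how a carboxylic acid, an amine or a longer alkyl chain would fare on this carbonyl carbon also remains open.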